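The source may report more compounds than this note shows. Statements on the series, on what has been measured and on what is new or still open speak of the compounds shown alone.

For the measured compounds named here, compound 2 `Cc1ccccc1C(Oc1cc(OCc2ccc3c(c2)OCCO3)ccc1C#N)C(=O)O` gives 1500 nM in an assay on A10 cells for antagonist activity at Endothelin-1 receptor (Rattus norvegicus) (on this read-out lower numbers stand for stronger inhibition and higher numbers for weaker inhibition), the higher of the two numbers measured so far, although the step of a 1.8-fold higher number from compound 1 to compound 2 (0.24 log units; within the scatter) lies within the scatter, compound 1 `Cc1ccccc1C(Oc1cc(OCc2c(C)cccc2C)ccc1C#N)C(=O)O` giving 857 nM in this assay. Compound 3 `Cc1ccccc1C(Oc1cc(OCc2ccnc(F)c2)ccc1C#N)C(=O)O` differs from compound 2 by 2-fluoropyridin-4-yl in place of 2,3-dihydro-1,4-benzodioxin-6-yl on a saturated chain carbon bound to an oxygen on an aromatic ring. Going by the values given here, no measured step exchanges this group for a pyridine; the only exchange at this place, a 1.8-fold higher number from compound 1 to compound 2 (0.24 log units; within the scatter), stayed within the scatter, so no step beyond the scatter in either direction is expected in this assay. Compound 3 is therefore estimated at 1500 nM, with a range from 500 nM to 4500 nM. That estimate means an expected step of no change at the digits printed from compound 2 to compound 3 (within the scatter).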

Compound 3, half-maximal inhibitory concentration: 23 nM
Estimate against measurement, compound 3: 65-fold (1.81 log units) above, outside the stated range (below it).
By their numbers in this assay, from the lowest: compound 3; then compounds 1 and 2 (each within the scatter of the next).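

At this place, on a saturated chain carbon bound to an oxygen on an aromatic ring, the group can strongly move the read-out in this assay: 2-fluoropyridin-4-yl gives a 65-fold lower number from compound 2 to compound 3 (1.81 log units; beyond the scatter) and a 37-fold lower number from compound 1 to compound 3 (1.57 log units; beyond the scatter), whereas the earlier exchange stayed within the scatter. The two groups it replaces therefore read alike here, while the new group stands clearly apart from both. Nothing given here explains this gain.

As far as these compounds go, whether the ring nitrogen, the fluorine or both carry the gain stays open, as compound 3 brings them in together. From the compounds shown here alone, how a plain pyridin-4-yl or a fluorophenyl would read at this place also remains unknown.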